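This account rests on a few compounds, and the source may have more. Where it says the series, first, only, none or still open, it means among the compounds named here.

Compound 1, `NCC(=O)Nc1cc2cc[nH]c(=O)c2cc1Cl`, gives 2500 nM in a functional assay (aorta) with Rattus norvegicus as the target; on this read-out higher numbers stand for an effect only at larger amounts of compound and lower numbers for an effect already at smaller amounts.
Compound 2, `O=C(Nc1cc2cc[nH]c(=O)c2cc1Cl)[C@H]1CCCN1`, gives 1120 nM in this assay.

Going by the values given here, of the two measured compounds, compound 2 has the lower number, and the only measured step, a 2.2-fold lower number from compound 1 to compound 2 (0.35 log units; beyond the scatter), separates it from compound 1. Compound 3, `CN1CCC(C(=O)Nc2cc3cc[nH]c(=O)c3cc2Cl)CC1`, differs from compound 2 in one place: 1-methylpiperidin-4-yl in place of pyrrolidin-2-yl on a carbonyl carbon. Among the compounds with values here, only one measured step exists to guide an expectation, and it concerns the same position on the shared core: going from compound 1 to compound 2 the group on the carbonyl carbon was exchanged and the number fell modestly. Within the data shown here, that step does not involve the group that enters here, so it shows only that this position tolerates exchange of the group without a large change in the number. A step of modest size in either direction, or none beyond the scatter, is therefore expected for compound 3, with the estimate a 1.3-fold higher number from compound 2 to compound 3 (0.10 log units; within the scatter). Compound 3 is expected to give about 1400 nM in this assay, within a range from 400 nM to 5000 nM.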

Compound 3, half-maximal effective concentration: 250 nM
Compound 3: middle estimate off by 5.6-fold (0.75 log units), on the high side; measured number outside the range, below it.
By their numbers in this assay, from the lowest: compound 3; then compound 2; then compound 1.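

The position on the carbonyl carbon can shift the number by more than the first step suggested: in this assay there is a 4.5-fold lower number from compound 2 to compound 3 (0.65 log units; beyond the scatter), and across the measured groups there is a 10-fold lower number from compound 1 to compound 3 (1.00 log units; beyond the scatter). With all three steps beyond the scatter, the order in this small set runs from aminomethyl through pyrrolidin-2-yl to 1-methylpiperidin-4-yl, so a change at this one place is enough to separate the compounds clearly, yet the latest exchange alters several things at once: the ring grows from five-membered to six-membered, the heavy-atom count rises, the hydrogen-bond donor of the pyrrolidin-2-yl group is gone, and so is its defined stereocentre. Nothing available here explains why the number falls with this exchange.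

Which of those differences matters remains open, and a piperidin-4-yl group without the methyl on its nitrogen, set against compound 3, would separate the methyl group from the ring. A 1-methylpyrrolidin-2-yl group, set against compound 2, would ask the same question of the methyl group on the smaller ring.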